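A few compounds are considered here, and "the series" means these few. Any claim that something is new, unique, unknown or untested is made for them only; others in the source may bear on it.

The measured compounds so far:

compound 1, `O=S1(=O)N=C(NC2CC2)Nc2ccc(Cl)cc21`: 190 uM
compound 2, `O=S1(=O)N=C(NC2CCC2)Nc2ccc(Cl)cc21`: 34.9 uM
compound 3, `O=S1(=O)NC(NC2CC2)=Nc2ccc(Br)cc21`: 89.4 uM

All three were tested in a functional assay (aorta) with Rattus norvegicus as the target; on this read-out higher numbers stand for an effect only at larger amounts of compound and lower numbers for an effect already at smaller amounts. Compound 4, `O=S1(=O)NC(NC2CCC2)=Nc2ccc(Br)cc21`, is not yet measured. It differs from compound 3 by cyclobutyl in place of cyclopropyl on an amine nitrogen. The same change, (cyclobutyl in place of cyclopropyl on an amine nitrogen), was already made from compound 1 to compound 2, where it gave a 5.4-fold lower number from compound 1 to compound 2 (0.74 log units; beyond the scatter). The place of the change is the same in both pairs; how the core of compound 1 differs from the core of compound 3 is not broken down here. Because that earlier step was a 5.4-fold lower number from compound 1 to compound 2 (0.74 log units; beyond the scatter), a similar step is expected from compound 3 to compound 4, namely a 5.3-fold lower number from compound 3 to compound 4 (0.72 log units; beyond the scatter). Compound 4 is therefore estimated at 17 uM in this assay, expected between 7 uM and 40 uM.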

Compound 4, concentration for half-maximal effect: 21.7 uM
Compound 4: the middle estimate sits 1.3-fold (0.11 log units) below what was measured; low and high end bracket the measured number.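

Cyclobutyl in place of cyclopropyl on an amine nitrogen gave a 4.1-fold lower number from compound 3 to compound 4 (0.61 log units; beyond the scatter) in this assay and so repeated on a second core the direction seen on the first. The change therefore carried over between these two cores with a similar size: the same change on two cores in this assay, a 5.4-fold lower number (0.74 log units; beyond the scatter) from compound 1 to compound 2 and a 4.1-fold lower number (0.61 log units; beyond the scatter) from compound 3 to compound 4, 1.3-fold (0.12 log units) apart, within the scatter of two such steps. Among these compounds, this rests on only two pairs, so it does not show that the step would hold on any further core, and it does not explain why the number drops.

The compounds shown leave open how a larger ring such as cyclopentyl, or an open chain such as isopropyl, would read on the same nitrogen. They also leave open whether the step would persist with fluorine or methyl in place of the chlorine or bromine.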